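A few compounds are considered here, and "the series" means these few. Any claim that something is new, unique, unknown or untested is made for them only; others in the source may bear on it.

Compound 1 `CNC(=O)c1cc(Oc2ccc3c(C)c(-c4noc(C(F)(F)F)n4)sc3c2)ccn1`: > 100000 nM
Compound 2 `CNC(=O)c1cc(Oc2ccc(-c3noc(C)n3)cc2)ccn1`: > 100000 nM
Compound 3 `CNC(=O)c1cc(Oc2ccc(-c3noc(C4CC4)n3)cc2)ccn1`: 32300 nM

These values come from an ADME assay on H1-HeLa cells (Homo sapiens) for cytotoxicity, read by MTT assay, with a stated time of 3 days; on this read-out higher numbers stand for lower toxicity in this test and lower numbers for higher toxicity in this test. Compound 2 gives > 100000 nM, which is a limit and not a number. Compound 1 gives > 100000 nM, which is also a limit. Compound 2 therefore stands at the limit of > 100000 nM in this assay, at which 2 of the 3 values shown sit.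

Compound 4 `CNC(=O)c1cc(Oc2ccc(-c3noc(C(F)(F)F)n3)cc2)ccn1` has not yet been measured. It carries trifluoromethyl in place of methyl on an aromatic carbon.

Among the compounds with values here, one measured step bears on this change, with cyclopropyl in place of methyl at the same carbon: an at least 3.0-fold lower number from compound 2 to compound 3 (0.49 log units; beyond the scatter). It involves a different group, so it offers only a loose guide. Compound 1 also carries trifluoromethyl on such a carbon, but its core is different. A modest move towards a lower number in this assay is expected, on the strength of compound 3 at 32300 nM. Compound 4 may also reach the limit. The estimated step is an at least 1.4-fold lower number from compound 2 to compound 4 (0.15 log units; that floor lies within the scatter). For compound 4 the estimated value is 70000 nM, with an expected range from 25000 nM to 100000 nM.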

Compound 4, half-maximal cytotoxic concentration: 35000 nM
For compound 4 the middle estimate is 2.0-fold (0.30 log units) above the measured one; the measured number falls inside the stated range.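

In this assay, trifluoromethyl in place of methyl on this aromatic carbon gives an at least 2.8-fold lower number from compound 2 to compound 4 (0.45 log units; beyond the scatter), so a second group, after cyclopropyl, brings a measured number on the shared core. The two groups cannot be told apart at this carbon, since the comparison gives a 1.1-fold higher number from compound 3 to compound 4 (0.03 log units; within the scatter) and that step lies within the scatter. Compound 2 remains a limit, so the size of the first step is only a floor: the limit of > 100000 nM in this assay, at which 2 of the 4 values shown sit.

Going by these compounds, it stays open whether an amine, a carboxylic acid or a longer chain on this carbon would give a number in the same range or return to the limit. Compound 1, which also carries trifluoromethyl but on a different core, gives > 100000 nM, which is a limit, and it differs from compound 4 in more than one place, so what the core contributes remains unresolved.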